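Swapping Chloro for Nitro on the Phenoxy Ring

A few compounds are considered here, and "the series" means these few. Any claim that something is new, unique, unknown or untested is made for them only; others in the source may bear on it.

Two compounds sharing one core have been examined in a functional assay on A549 cells (Homo sapiens) for inhibition, read by MTT assay, with a stated time of 48 h; a lower number here means a stronger inhibitor, a higher number a weaker inhibitor. Compound 1, `CCOC(=O)c1cc(-c2ccc(Cl)cc2)nn1CC(O)COc1ccc([N+](=O)[O-])cc1`, gives 45000 nM in this assay. Compound 2, `CCOC(=O)c1cc(-c2ccc(OC)cc2)nn1CC(O)COc1ccc(Cl)cc1`, gives 38000 nM in this assay. Compound 2 holds the lower of the two numbers, but its gap to compound 1 lies within the usual scatter, so the two compounds cannot be told apart on these figures.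

The next compound, compound 3, `CCOC(=O)c1cc(-c2ccc(OC)cc2)nn1CC(O)COc1ccc([N+](=O)[O-])cc1`, differs from compound 2 in one place: nitro in place of chloro on an aromatic carbon, turning 4-chlorophenoxy into 4-nitrophenoxy. Among the compounds with values here, no pair of measured compounds shows this change on its own, so there is no measured step to lean on, and compound 1 and compound 2 differ from each other in two places at once. What they do show is that compound 1, carrying 4-nitrophenoxy, and compound 2, carrying 4-chlorophenoxy, land in the same range. The change is therefore expected to bring no step beyond the scatter, the expected step being a 1.1-fold higher number from compound 2 to compound 3 (0.02 log units; within the scatter). Compound 3 is estimated at 40000 nM in this assay, with a range from 20000 nM to 80000 nM.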

Compound 3, half-maximal inhibitory concentration: 44000 nM
Compound 3: the middle estimate sits 1.1-fold (0.04 log units) below what was measured; low and high end bracket the measured number.
By their numbers in this assay, from the lowest: compounds 2, 3 and 1 (each within the scatter of the next).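

In this assay, the swap of nitro for chloro on the phenoxy ring now has a measured step of its own. That step is a 1.2-fold higher number from compound 2 to compound 3 (0.06 log units; within the scatter) and lies within the scatter, so with the methoxy group held in place, 4-chlorophenoxy and 4-nitrophenoxy cannot be told apart at this position. The same compound also opens a second single change, with chloro leaving and methoxy entering, read as a 1.0-fold lower number from compound 1 to compound 3 (0.01 log units; within the scatter) and likewise within the scatter, so with 4-nitrophenoxy held in place, chloro and methoxy cannot be told apart at that site either. Nothing available bears on why either change leaves the number within the scatter.

Each position is so far covered by only these two groups, and all three compounds sit within the scatter of one another, so neither site has yet been seen to matter. From the compounds shown here alone, whether an amine or a carboxylic acid in place of the nitro or chloro on the phenoxy ring, or a longer chain on the ester, would bring a step beyond the scatter remains open.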